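Removing the Isopropyl Group: What Compound 4 Might Retain

This account rests on a few compounds, and the source may have more. Where it says the series, first, only, none or still open, it means among the compounds named here.

This account concerns a small set of compounds sharing one core and differing only in a single substituent on an aromatic carbon. In an ADME assay on microsomes from liver (Homo sapiens) for metabolic stability, with a stated time of 60 min, tested at 1 uM (on this read-out higher numbers stand for a more stable compound and lower numbers for a less stable compound), compound 1 `COc1cc(-c2cnn3cc(OC)c(C(C)C)nc23)ccn1` gives 40%, the highest of the three measured numbers. Compound 2 `COc1cc(-c2cnn3cc(OC)c(C4CCOC4)nc23)ccn1` gives 29%, and compound 3 `COc1cc(-c2cnn3cc(OC)c(N(C)C)nc23)ccn1` gives 16%. The steps among them are all downward from compound 1: a number 11 percentage points lower from compound 1 to compound 2 (beyond the scatter) and a number 24 percentage points lower from compound 1 to compound 3 (beyond the scatter), with a number 13 percentage points lower from compound 2 to compound 3 (beyond the scatter) between the other two.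

Compound 4 `COc1cnc2c(-c3ccnc(OC)c3)cnn2c1` carries a different change at the same carbon: hydrogen in place of isopropyl on an aromatic carbon. For the measured compounds named here, no measured step removes the isopropyl group outright; the two steps from compound 1 only swap it for another group, and both lowered the number modestly. Since every departure from the isopropyl group seen so far has cost stability, a modest drop is expected for compound 4 as well, though a hydrogen is not covered by the measured steps, so the range is wide. The expected step is a number 8 percentage points lower from compound 1 to compound 4 (within the scatter). Compound 4 is therefore estimated at 32%, between 15% and 50%.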

Compound 4, percent of the compound remaining: 2%
Estimate against measurement, compound 4: 30 percentage points above, outside the stated range (below it).
By their numbers in this assay, from the lowest: compound 4; then compound 3; then compound 2; then compound 1.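

In this assay, this carbon proves to matter even more than the earlier swaps suggested: hydrogen in place of isopropyl is a large step (a number 38 percentage points lower from compound 1 to compound 4 (beyond the scatter)), where the replacements by other groups were modest. Compound 4 also falls short of the two compounds carrying other groups at this carbon (a number 27 percentage points lower from compound 2 to compound 4 (beyond the scatter); a number 14 percentage points lower from compound 3 to compound 4 (beyond the scatter)), so among the four compounds, each of the three substituents leaves more of the compound remaining than hydrogen does. Nothing available explains why removing the isopropyl group has this effect.

The compounds shown leave open whether a methyl or cyclopropyl group at this carbon would keep the number of compound 1 or lose part of it. They also cannot say whether a tert-butyl group would raise it further.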